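The source may report more compounds than this note shows. Statements on the series, on what has been measured and on what is new or still open speak of the compounds shown alone.

Of the compounds shown here, three of a shared core have been measured in an ADME assay on HepG2 cells (Homo sapiens) for cytotoxicity, with a stated time of 72 h; a lower number here means that less compound is needed, a higher number that more compound is needed for the effect.
Compound 1, `Cc1cc(NC(=O)Nc2ccc(F)cc2)c2ccccc2n1`, gives in this assay only the limit > 25000 nM.
Compound 2, `Cc1cc(NC(=O)Nc2ccc(F)cc2F)c2ccccc2n1`, gives in this assay a value of 17000 nM.
Compound 3, `Cc1cc(NC(=O)Nc2cccnc2)c2ccccc2n1`, gives in this assay only the limit > 25000 nM.

Compound 1 thus stands not at a number but at a limit of the assay, and the same holds for (the limit of > 25000 nM in this assay, at which 2 of the 3 values shown sit). Among the compounds with values here, the one step from compound 1 that can be read at all, an at least 1.4-fold lower number from compound 1 to compound 2 (0.16 log units; that floor lies within the scatter), comes with fluoro in place of hydrogen on an aromatic carbon and reaches only a floor that lies within the scatter. The other step, a step that the two limits leave unreadable from compound 1 to compound 3, pairs two limits and cannot be sized.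

Compound 4, `Cc1cc(NC(=O)Nc2ccc(C(F)(F)F)cc2)c2ccccc2n1`, differs from compound 1 as follows: trifluoromethyl in place of fluoro on an aromatic carbon. Within the data shown here, neither measured step bears directly on trifluoromethyl in place of fluoro, and the one step that could be read did not leave the scatter. No step beyond the scatter is expected in this assay, in either direction, so compound 4 is expected to sit again at or near the limit. The expected step is a number no higher from compound 1 to compound 4 (the limit leaves the size open). Compound 4 is estimated at 25000 nM, within a range from 12000 nM to 50000 nM.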

Compound 4, half-maximal effective concentration: 23000 nM
The estimate for compound 4 lay 1.1-fold (0.04 log units) above the measured number, within the range that was stated.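

In this assay, within the data shown here, the new result is the first to concern the group para to a large group itself, rather than an added fluoro or an exchange of the whole aryl group: trifluoromethyl in place of fluoro on this aromatic carbon gives an at least 1.0-fold lower number from compound 1 to compound 4 (0.03 log units; that floor lies within the scatter). Compound 4 therefore shows that this exchange, which brings in more heavy atoms but no ring, hydrogen-bond donor, hydrogen-bond acceptor or net charge, produces no step shown to lie beyond the scatter. The size of the step remains open, since compound 1 gives only a limit and the step has only a floor, and that limit remains common among the compounds shown: the limit of > 25000 nM in this assay, at which 2 of the 4 values shown sit.

The compounds shown leave open whether a group of another kind at this place, such as an amine, a carboxylic acid or a longer chain, would bring a step beyond the scatter. They also leave open how far the number for compound 1 lies from that of compound 4, a question that only a number for compound 1 in place of its limit could settle.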